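Imidazopyrazine series: aryl swap at the core, single-dose screen

The source may report more compounds than this note shows. Statements on the series, on what has been measured and on what is new or still open speak of the compounds shown alone.

Measured so far:
compound 1 `c1ccc2c(-c3cn4ccnc4c(-c4ccc5ncn(C6CCCCC6)c5c4)n3)cccc2c1` 11.1%
compound 2 `CC(=O)c1ccc(-c2cn3ccnc3c(-c3ccc4ncn(C5CCCCC5)c4c3)n2)cc1` 11.7%

Both measured compounds share one core and differ only in the aryl group on the aromatic carbon. In a functional assay on KM12 cells (Homo sapiens) for inhibition, read by sulforhodamine B assay, with a stated time of 48 h, tested at 10 uM (on this read-out lower numbers stand for less inhibition and higher numbers for more inhibition at the one concentration tested (going by the name of the read-out)), compound 1 gives 11.1% and compound 2 gives 11.7%. Among the measured compounds shown here, the only measured step, a number 0.6 percentage points higher from compound 1 to compound 2 (within the scatter), shows that replacing naphthalen-1-yl with 4-acetylphenyl leaves the read-out where it was. Compound 2 thus stands at the higher of two numbers, but its gap to compound 1 is within the scatter, so no order between the two can be stated.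

Compound 3 `Fc1ccccc1-c1cn2ccnc2c(-c2ccc3ncn(C4CCCCC4)c3c2)n1` is not yet measured. Its change from compound 2 is 2-fluorophenyl in place of 4-acetylphenyl on an aromatic carbon. For the measured compounds named here, the one measured step bears on this directly, since it also exchanges the aryl group at the same place, and it was flat. No step beyond the scatter has been seen for this position, so the expectation for compound 3 in this assay is a step of a number 0.3 percentage points higher from compound 2 to compound 3 (within the scatter), that is, none beyond the scatter. Compound 3 is estimated at 12%, with a range from 0% to 30%.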

Compound 3, a percentage reported as inhibition, at one concentration (the size of the read-out at that concentration, not a potency): 2.45%
Estimate against measurement, compound 3: 9.6 percentage points above; the range from low to high includes it.
By their numbers in this assay, from the lowest: compounds 3, 1 and 2 (each within the scatter of the next).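

In this assay, 2-fluorophenyl in place of 4-acetylphenyl gives a number 9.3 percentage points lower from compound 2 to compound 3 (within the scatter), and 2-fluorophenyl in place of naphthalen-1-yl gives a number 8.7 percentage points lower from compound 1 to compound 3 (within the scatter), so all three aryl groups at this position now sit within the scatter of one another. The new point is that this change removes the acetyl carbonyl, the hydrogen-bond acceptor of the leaving group, and brings in a fluorine on the ring without any step beyond the scatter, which extends the flat picture from two aryl groups to three but does not show that the position is insensitive to other kinds of group. No supporting measurement is available to account for this flat result.

Still open, from the compounds shown here alone, is whether a phenyl ring carrying an amine or a carboxylic acid, or a saturated morpholine ring in place of the aryl group, would produce a step beyond the scatter at this position. Since the read-out comes from one concentration, it also leaves open whether these three compounds would differ in potency across a full concentration range.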